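Swapping the pyrrolidine for a substituted piperidine

The source may report more compounds than this note shows. Statements on the series, on what has been measured and on what is new or still open speak of the compounds shown alone.

Compound 1, with the structure `CC(C(=O)NCc1ccc(C(F)(F)F)nc1N1CCCC1)c1ccc(NS(C)(=O)=O)c(F)c1`, is the reference point of this small set. In a functional assay on CHO-K1 cells for antagonist activity at transient receptor potential cation channel subfamily V member 1 (Homo sapiens), read by FLIPR (a lower number here means a stronger inhibitor, a higher number a weaker inhibitor), compound 1 gives 0.6 nM, the lowest number of the three measured compounds. Compound 2, `C[C@H](C(=O)NCc1ccc(C(F)(F)F)nc1N1CC[C@@H](OCc2ccccc2)C1)c1ccc(NS(C)(=O)=O)c(F)c1`, gives 1.4 nM, and compound 3, `C[C@@H](C(=O)NCc1ccc(C(F)(F)F)nc1N1CCC(c2ccccc2)CC1)c1ccc(NS(C)(=O)=O)c(F)c1`, gives 7.5 nM; both of these carry groups on the shared core that go beyond a plain pyrrolidin-1-yl, and both return higher numbers than compound 1, with the piperidine-bearing compound 3 furthest away.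

Compound 4, `CC(C(=O)NCc1ccc(C(F)(F)F)nc1N1CCC(CN(C)C)CC1)c1ccc(NS(C)(=O)=O)c(F)c1`, is not yet measured. The change from compound 1 is 4-((dimethylamino)methyl)piperidin-1-yl in place of pyrrolidin-1-yl on an aromatic carbon. A five-membered non-aromatic ring gives way to a six-membered non-aromatic ring bearing a (dimethylamino)methyl arm, a larger group that also brings an additional hydrogen-bond acceptor.

The two measured departures from compound 1 both gave weaker inhibition, so a step toward a higher number is expected here as well, of a size between those seen for compound 2 and compound 3, as a 6.7-fold higher number from compound 1 to compound 4 (0.82 log units; beyond the scatter). Compound 4 is therefore estimated at 4 nM, with a likely range from 1 nM to 20 nM.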

Compound 4, inhibition constant: 2.1 nM
Compound 4: middle estimate off by 1.9-fold (0.28 log units), on the high side, and the stated range covers the measured number.
By their numbers in this assay, from the lowest: compound 1; then compounds 2 and 4 (each within the scatter of the next); then compound 3.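

Among the compounds shown here, this is the first change at this position that can be read on its own: 4-((dimethylamino)methyl)piperidin-1-yl in place of pyrrolidin-1-yl gives a 3.5-fold higher number from compound 1 to compound 4 (0.54 log units; beyond the scatter) in this assay. The entering group has 10 heavy atoms against 5 for the one it replaces, yet compound 4 still gives 2.1 nM, so this aromatic carbon next to the ring nitrogen accepts a much larger group at a modest cost. Nothing measured here bears on why the step has this size.

From the compounds shown here alone, the ring size and the (dimethylamino)methyl arm change together in this step, so their separate shares stay open. A plain piperidin-1-yl would separate the two, and a morpholin-4-yl would show how a ring oxygen fares at this position.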